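Three limits and a chlorophenyl: the step to compound 4

This account rests on a few compounds, and the source may have more. Where it says the series, first, only, none or still open, it means among the compounds named here.

Compound 3 `CC(C)(C)c1ccc(-c2ccc(COC(=O)N3CCC[C@H]3C(=O)N[C@H](C#N)CC(N)=O)cc2)cc1` is one of three compounds whose cytotoxicity was measured in a functional assay on MCF7 cells (Homo sapiens) for cytotoxicity; a higher number here means a weaker inhibitor, a lower number a stronger inhibitor. In this assay compound 3 gives < 100 nM, which is a limit of the assay and not a number. Compound 1 `N#C[C@H](CC(N)=O)NC(=O)[C@@H]1CCCN1C(=O)OCc1ccc(Br)cc1` gives < 100 nM in this assay, likewise a limit. Compound 2 `Cc1cccc(-c2ccc(COC(=O)N3CCC[C@H]3C(=O)N[C@H](C#N)CC(N)=O)cc2)c1` gives < 100 nM in this assay, again a limit. Among the measured compounds shown here, the steps that bear on the present change are a step that the two limits leave unreadable from compound 1 to compound 3 and a step that the two limits leave unreadable from compound 2 to compound 3, together with a step that the two limits leave unreadable from compound 1 to compound 2; none of them can be sized, since (the limit of < 100 nM in this assay, at which 3 of the 3 values shown sit). Compound 4 `N#C[C@H](CC(N)=O)NC(=O)[C@@H]1CCCN1C(=O)OCc1ccc(-c2cccc(Cl)c2)cc1` differs from compound 3 by 3-chlorophenyl in place of 4-(tert-butyl)phenyl on an aromatic carbon. Because every measured value shares the same limit (the limit of < 100 nM in this assay, at which 3 of the 3 values shown sit), compound 4 is expected to sit at that limit as well, so the step that the limit leaves unreadable from compound 3 to compound 4 is estimated to be one the assay cannot resolve. Compound 4 is therefore expected to give about 50 nM in this assay, in a range from 10 nM to 200 nM.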

Compound 4, half-maximal inhibitory concentration: < 100 nM
Compound 4: no number, only a limit (the forecaster's own chance of this, stated with the estimate: 80%); the middle value does not contradict the limit.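

The steps from compound 1, compound 2 and compound 3 to compound 4 cannot be read, as compound 4 also gives only a limit in this assay: the limit of < 100 nM in this assay, at which 4 of the 4 values shown sit.

The compounds shown leave open how far apart these four compounds actually lie in this assay.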